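Removing a Chloro From a Dichlorinated Benzyl Purine Analogue

The source may report more compounds than this note shows. Statements on the series, on what has been measured and on what is new or still open speak of the compounds shown alone.

Measured so far:
Compound 1, `ClCc1cccc(Cn2cnc3c(Cl)ncnc32)c1`: 2450 nM
Compound 2, `ClCc1ccc(Cn2cnc3nc(Cl)nc(Cl)c32)cc1`: 2080 nM

In a functional assay on NCI/ADR-RES cells (Homo sapiens) for cytotoxicity, read by sulforhodamine B assay, with a stated time of 48 h (a higher number here means a weaker inhibitor of growth, a lower number a stronger inhibitor of growth), compound 2 gives 2080 nM, the lowest of the two numbers. Compound 1 gives 2450 nM in this assay, and the two values sit within the usual scatter of each other, so no order between them can be read from the data.

Compound 3, `ClCc1ccc(Cn2cnc3ncnc(Cl)c32)cc1`, has not yet been measured. It differs from compound 2 by hydrogen in place of chloro on an aromatic carbon. For the measured compounds named here, no step of this kind has been measured among the compounds at hand, so the size of the effect is not known from these data. Compound 1, which also carries a single chloro on the core and gives 2450 nM, suggests that one chloro on this part of the core does not change the number much. The step of a 1.3-fold higher number from compound 2 to compound 3 (0.13 log units; within the scatter) is therefore expected to be small, likely within the scatter, if anything toward a slightly higher number. Compound 3 is estimated to give 2800 nM, with a range from 1200 nM to 6500 nM.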

Compound 3, concentration for 50% growth inhibition: 1810 nM
Beside the measured number, compound 3's estimate is 1.5-fold (0.19 log units) above it; the range from low to high includes it.
By their numbers in this assay, from the lowest: compounds 3, 2 and 1 (each within the scatter of the next).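

In this assay, placing hydrogen in place of chloro on the aromatic carbon between two ring nitrogen atoms gives a 1.1-fold lower number from compound 2 to compound 3 (0.06 log units; within the scatter), a step within the scatter. For the compounds shown here, this is the first measured step at this position, and it shows that the chloro there can be lost without a change that the assay can resolve. Compound 3 therefore keeps growth inhibition in the same range with one chloro fewer on the shared core, but no measurement at hand explains this result.

Only chloro and hydrogen appear at this position among the compounds shown, so the step says nothing yet about how an amine or a methoxy group would behave there. On these data alone, whether any other group at this carbon would move the number beyond the scatter remains open.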